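Difluoromethyl aryl swap on a sulfamoylacetamide oxadiazole

The compounds below may be only part of what the source reports. "The series", "measured", "known", "first", "only" and "open" are said of these compounds alone.

Compound 1 `NS(=O)(=O)CC(=O)NCCSc1nonc1/C(=N/O)Nc1cccc(Cl)c1` is characterised in an ADME assay on isolated protein for pharmacokinetics, with UDP-glucuronosyltransferase 1A9 (Homo sapiens) as the target, read by LC-MS, with a stated time of 60 min, at 37 degrees C, tested at 1 uM, in the presence of a further agent that is not named here (on this read-out lower numbers stand for a shorter-lived compound and higher numbers for a longer-lived compound), where compound 1 gives 0.9 h. That number is the second highest of three: compound 3 `C[C@H](CSc1nonc1/C(=N/O)Nc1ccc(F)c(Br)c1)NC(=O)CS(N)(=O)=O`, bearing a related linker, gives 1.33 h, which lies within the scatter of compound 1, whereas compound 2 `NS(=O)(=O)NCCSc1nonc1/C(=N/O)Nc1ccc(F)c(Br)c1`, with a different linker, gives 0.183 h, a gap beyond the scatter. Compound 4 `NS(=O)(=O)CC(=O)NCCSc1nonc1/C(=N/O)Nc1ccc(F)c(C(F)F)c1` keeps the linker of compound 1 and changes only the aryl group: 3-(difluoromethyl)-4-fluorophenyl in place of 3-chlorophenyl on an amine nitrogen. Going by the values given here, no measured pair isolates this aryl change. Since compound 1 and compound 3 carry different aryl groups yet stand within scatter of each other, the step from compound 1 to compound 4 is expected to be small, a 1.1-fold higher number from compound 1 to compound 4 (0.05 log units; within the scatter), with no change beyond the scatter. Compound 4 is therefore estimated at 1 h, within 0.5 h to 2 h.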

Compound 4, half-life: > 3 h
Compound 4: no number, only a limit; the forecaster's own chance of this, stated with the estimate: 5%; middle value at least 3.0-fold (0.47 log units) away from the limit.
By their numbers in this assay, from the lowest: compound 2; then compounds 1 and 3 (each within the scatter of the next). At a limit, above all of these: compound 4.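

In this assay, the aryl group on an amine nitrogen proves to matter with the linker held fixed: 3-(difluoromethyl)-4-fluorophenyl in place of 3-chlorophenyl brings an at least 3.3-fold higher number from compound 1 to compound 4 (0.52 log units; beyond the scatter). Going by these compounds alone, the earlier compounds offered no pair that isolated a change at this position, so this is the first single-place step there. The result for compound 4 is a limit and not a number: the limit of > 3 h in this assay, at which 1 of the 4 values shown sits.

On these data alone, how far the step reaches stays open. So does whether a trifluoromethyl or a nitrile in place of the difluoromethyl would give a step of like size on this linker.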